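A few compounds are considered here, and "the series" means these few. Any claim that something is new, unique, unknown or untested is made for them only; others in the source may bear on it.

Among the compounds with values here, compound 2 `O=C(NS(=O)(=O)CCNC(=O)C1CC1)c1ccc(Nc2nc(NC3(c4ccc(Cl)cc4)CC3)nc(OCC(F)(F)F)n2)cc1` is one of two compounds so far measured in an ADME assay on microsomes from liver (Homo sapiens) for metabolic stability, with a stated time of 10 min; on this read-out higher numbers stand for a more stable compound and lower numbers for a less stable compound. In this assay compound 2 gives 90%, the lower of the two figures; its nearest neighbour, compound 1 `CC(C)(C)OC(=O)NCCS(=O)(=O)NC(=O)c1ccc(Nc2nc(NC3(c4ccc(Cl)cc4)CC3)nc(OCC(F)(F)F)n2)cc1`, gives 92%, and the two numbers lie within the scatter of each other. Compound 3 `CC(C)NC(=O)NCCS(=O)(=O)NC(=O)c1ccc(Nc2nc(NC3(c4ccc(Cl)cc4)CC3)nc(OCC(F)(F)F)n2)cc1` has not yet been measured in this assay. It differs from compound 2 in one place: isopropylamino in place of cyclopropyl on a carbonyl carbon. Within the data shown here, only one measured step bears on this position, the exchange of cyclopropyl for tert-butoxy on the same carbonyl carbon, and that exchange gave a number 2 percentage points lower from compound 1 to compound 2 (within the scatter). With that step staying within the scatter, the present exchange of isopropylamino for cyclopropyl on the carbonyl carbon is expected to behave alike, and the expected step is a number 2 percentage points lower from compound 2 to compound 3 (within the scatter). Compound 3 is therefore estimated at 88%, with a range from 72% to 98%.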

Compound 3, percent of the compound remaining: 100%
Compound 3: the middle estimate sits 12 percentage points below what was measured; the whole stated range lies below it.
By their numbers in this assay, from the lowest: compounds 2, 1 and 3 (each within the scatter of the next).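

In this assay, exchanging the group on the carbonyl carbon for isopropylamino produces no step beyond the scatter: a number 10 percentage points higher from compound 2 to compound 3 (within the scatter) and a number 8 percentage points higher from compound 1 to compound 3 (within the scatter). The position has now carried cyclopropyl, with its three-membered ring of carbon only, tert-butoxy, and isopropylamino, which has no ring and brings a nitrogen and a hydrogen-bond donor, and none of these exchanges separates the compounds in this read-out. Nothing available here gives a reason for these figures.

As far as these compounds go, it remains open whether a carboxylic acid, a primary amine or a longer alkyl chain on this carbonyl carbon would stay within the scatter of these three compounds. From the compounds shown here alone, it is also open whether an exchange elsewhere on the shared core would give a step beyond the scatter in this assay.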